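From isopropylcarbamoyl to ethylcarbamoyl: a small trim

The compounds below may be only part of what the source reports. "The series", "measured", "known", "first", "only" and "open" are said of these compounds alone.

Measured so far in a functional assay on K562 cells (Homo sapiens) for antiproliferative activity, read by CCK-8 assay, with a stated time of 72 h; a higher number here means a weaker inhibitor of growth, a lower number a stronger inhibitor of growth
- compound 1 `CCC1C(=O)N(C)c2cnc(-n3ccc4cc(C(=O)NC(C)C)ccc43)nc2N1c1ccn(C)n1` gives 8910 nM
- compound 2 `CCCNS(=O)(=O)c1ccc(Nc2ncc3c(n2)N(c2ccn(C)n2)C(CC)C(=O)N3C)cc1` gives 2260 nM
- compound 3 `CCC1C(=O)N(C)c2cnc(Nc3ccc(S(N)(=O)=O)cc3)nc2N1c1ccn(C)n1` gives "not active" (no number reported)

Of the two numbers available, compound 1 holds the higher one, which makes it the weaker growth inhibitor of that pair. Compound 2 at 2260 nM lies lower by more than the usual scatter, while compound 3 offers no number to compare.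

Compound 4 `CCNC(=O)c1ccc2c(ccn2-c2ncc3c(n2)N(c2ccn(C)n2)C(CC)C(=O)N3C)c1` differs from compound 1 by a single small edit, isopropylcarbamoyl to ethylcarbamoyl, counted as hydrogen in place of methyl on a saturated chain carbon bound to an amide-type nitrogen and a saturated chain carbon in the structures. This puts hydrogen in place of methyl on a saturated chain carbon bound to an amide-type nitrogen and a saturated chain carbon.

Among the compounds with values here, no measured pair here shows this kind of change on its own, so the forecast rests on compound 1 alone. Starting from compound 1 at 8910 nM a step within the scatter is expected in this assay with no clear direction. The expected change is a 1.1-fold lower number from compound 1 to compound 4 (0.05 log units; within the scatter) and no more than an estimate. For compound 4 the estimated value is 8000 nM with an expected range from 3000 nM to 20000 nM in this estimate.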

Compound 4, concentration for 50% growth inhibition: 12800 nM
Compound 4: middle estimate off by 1.6-fold (0.20 log units), on the low side, and the stated range covers the measured number.
By their numbers in this assay, from the lowest: compound 2; then compounds 1 and 4 (each within the scatter of the next).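

In this assay, within the data shown here, replacing isopropylcarbamoyl with ethylcarbamoyl gives a 1.4-fold higher number from compound 1 to compound 4 (0.16 log units; within the scatter), the first direct reading of a single change at this position. Losing this one methyl from the saturated chain carbon bound to an amide-type nitrogen therefore leaves a result that cannot be told apart from that of the parent compound, so this measurement does not separate the isopropyl and ethyl groups. Nothing available here bears on why the two compounds read alike.

Still open, from the compounds shown here alone, is whether a larger edit at the same place, such as a longer chain like n-butyl or a chain ending in an amine or a carboxylic acid, would move the number beyond the scatter. A single step also cannot show whether the same change would read alike on a different compound.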